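Trimethoxy variant of the indole dienone cytotoxicity series

The compounds below may be only part of what the source reports. "The series", "measured", "known", "first", "only" and "open" are said of these compounds alone.

Three members of the series have been measured. Compound 1 `COc1ccc2[nH]cc(C(=O)/C(C#N)=C/C=C(\Cl)c3ccc(Br)cc3)c2c1` gives 79900 nM in a functional assay on MCF7 cells (Homo sapiens) for cytotoxicity, read by sulforhodamine B assay, with a stated time of 48 h; on this read-out lower numbers stand for stronger inhibition of growth and higher numbers for weaker inhibition of growth. Compound 2 `N#C/C(=C\C=C(/Cl)c1ccc(Br)cc1)C(=O)c1c[nH]c2ccccc12` gives 72500 nM in this assay. Compound 3 `COc1ccc(/C(Cl)=C/C=C(\C#N)C(=O)c2c(C)[nH]c3ccccc23)cc1OC` gives 29600 nM in this assay, the lowest of the three numbers; its nearest neighbour is compound 2, and the difference between the cores of compound 3 and compound 2 is not broken down here.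

One change is seen twice in the set. Between the measured pair it is methoxy in place of hydrogen on an aromatic carbon, and it made a 1.1-fold higher number from compound 2 to compound 1 (0.04 log units; within the scatter). The unmeasured compound 4 `COc1cc(/C(Cl)=C/C=C(\C#N)C(=O)c2c(C)[nH]c3ccccc23)cc(OC)c1OC` carries the same kind of change relative to compound 3, (methoxy in place of hydrogen on an aromatic carbon). The surroundings are not the same: in the first case the place is part of a fused or bridged system of two rings, meta to a fused ring and para to a fused ring, whereas in the second it is ortho to a methoxy group, meta to a large group and meta to a methoxy group.

For compound 4 the step of a 1.2-fold lower number from compound 3 to compound 4 (0.07 log units; within the scatter) is expected, resting on compound 2 to compound 1 having given a 1.1-fold higher number from compound 2 to compound 1 (0.04 log units; within the scatter), a change within the scatter. Within the data shown here, compound 4 is therefore estimated at 25000 nM in this assay, with a likely range from 9000 nM to 70000 nM; only two measured pairs inform this, so the range is kept wide.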

Compound 4, concentration for 50% growth inhibition: < 100 nM
Compound 4 was reported as a limit; the forecaster's own chance of this, stated with the estimate: 5%; at least 250-fold (2.39 log units) between middle value and limit.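

In this assay, methoxy in place of hydrogen on an aromatic carbon gives an at least 290-fold lower number from compound 3 to compound 4 (2.47 log units; beyond the scatter), and the size of this change does not carry over from one core to the other: the same change on two cores in this assay, a 1.1-fold higher number (0.04 log units; within the scatter) from compound 2 to compound 1 and an at least 290-fold lower number (2.47 log units; beyond the scatter) from compound 3 to compound 4, at least 320-fold (2.51 log units) apart, beyond the scatter of two such steps

The value of compound 4 is a limit and not a number, so the full size of that step stays unfixed: the limit of < 100 nM in this assay, at which 1 of the 4 values shown sits.

The two pairs do not show whether the difference follows the core or the place of the new methoxy group, here ortho to a methoxy group, meta to a large group and meta to a methoxy group; each core supplies a single pair, so no general rule for this change in the series can be drawn.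

Open points: it remains unclear whether a different group at this same place, such as an ethoxy group, a hydroxy group or an amine, would give a step of similar size to that of the methoxy group. From the compounds shown here alone, it also remains open whether a methoxy group at the matching place on the core of compound 2 would give a large step, which would separate the effect of the place from that of the rest of the core.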